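Alkylsulfanyl chain length and fibroblast cytotoxicity in the series

The source may hold more compounds than are shown below. What is called first, only, known or untested is meant among the compounds shown, and "the series" means these compounds.

Measured compounds:
Compound 1 `Nc1nc(OCC(F)(F)F)c2ncn(/C=C3/CC3(CO)CO)c2n1`: in an ADME assay on HFF cells (Homo sapiens) for cytotoxicity, with a stated time of 8 days (on this read-out lower numbers stand for higher toxicity in this test and higher numbers for lower toxicity in this test), compound 1 gives > 300000 nM, a limit of the assay.
Compound 2 `CCCSc1nc(N)nc2c1ncn2/C=C1/CC1(CO)CO`: in this assay compound 2 gives > 300000 nM, a limit of the assay.
Compound 3 `CCCCCCCCSc1nc(N)nc2c1ncn2/C=C1/CC1(CO)CO`: in this assay compound 3 gives > 300000 nM, a limit of the assay.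

Compound 2 stands at the limit of this assay, and the two further values shown are limits too, so no order among the three compounds can be read. The steps between them are a step that the two limits leave unreadable from compound 1 to compound 2, a step that the two limits leave unreadable from compound 1 to compound 3 and a step that the two limits leave unreadable from compound 2 to compound 3; each is left unreadable by the two limits. Among the measured compounds shown here, the only evidence across the set is the limit of > 300000 nM in this assay, at which 3 of the 3 values shown sit.

Compound 4 `CCCCCCSc1nc(N)nc2c1ncn2/C=C1/CC1(CO)CO` is the unmeasured member. It differs from compound 2 by propyl in place of hydrogen on a saturated chain carbon, three bonds along the chain from a sulfur. For the measured compounds named here, the step that bears most directly on this change is the one from compound 2 to compound 3, where a longer chain enters at the same place; that step is unreadable. The step from compound 1 to compound 3 is unreadable as well.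

With every value shown sitting at the limit (the limit of > 300000 nM in this assay, at which 3 of the 3 values shown sit), compound 4 is expected to show no readable step, a number no higher from compound 2 to compound 4 (the limit leaves the size open). The estimate for compound 4 in this assay is 300000 nM, ranging from 150000 nM to 600000 nM, most probably reported as a limit again.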

Compound 4, half-maximal cytotoxic concentration: > 300000 nM
Compound 4 was reported as a limit; the forecaster's own chance of this, stated with the estimate: 85%; the middle value lies on the limit itself.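

Compound 4 gives a limit of the assay in this assay, as do compound 1, compound 2 and compound 3, so no new step can be read among them: the limit of > 300000 nM in this assay, at which 4 of the 4 values shown sit.

The compounds shown leave open whether the 2,2,2-trifluoroethoxy, propylsulfanyl, hexylsulfanyl and octylsulfanyl members differ at all in this assay, and whether chain length has any bearing on the read-out.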